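The source may report more compounds than this note shows. Statements on the series, on what has been measured and on what is new or still open speak of the compounds shown alone.

Measured in a physicochemical assay for lipophilicity; on this read-out higher numbers stand for higher lipophilicity and lower numbers for lower lipophilicity:
Compound 1 `CCn1cnc2c(-c3ccnc(Oc4cccc(S(=O)(=O)CC)c4)c3)cnnc21`: 1.6
Compound 2 `CCn1cnc2c(-c3ccc(F)c(-c4ccc(S(=O)(=O)CC)cc4)c3)cnnc21`: 2.9

Of these two numbers, compound 2 stands highest at 2.9, while compound 1 lies lower at 1.6, a gap beyond the usual scatter of repeated measurements. For the measured compounds named here, no two measured compounds differ in one place alone, so no measured step is available as a guide to the next one.

The account now turns to compound 3 `CCOc1cc(S(=O)(=O)CC)ccc1-c1cc(-c2cnnc3c2ncn3CC)ccc1F`, which has not yet been measured in this assay. It differs from compound 2 by one change: ethoxy in place of hydrogen on an aromatic carbon. In words, this is ethoxy in place of hydrogen on an aromatic carbon.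

The expectation therefore starts from compound 2 at 2.9 and rests on this structural change alone. A modest rise in this assay is expected, of a size only a little beyond the scatter, and a result within the scatter would not be surprising. The estimated step of a number 0.40 log units higher from compound 2 to compound 3 (beyond the scatter) is upward. Compound 3 is expected to give about 3.3, with an estimated range of 2.8 to 3.8.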

Compound 3, distribution coefficient: 3.3
Beside the measured number, compound 3's estimate shows no gap at the digits printed; the measured number falls inside the stated range.
By their numbers in this assay, from the lowest: compound 1; then compound 2; then compound 3.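

In this assay, the ring that carries the ethylsulfonyl group now has its first measured change: ethoxy in place of hydrogen on an aromatic carbon, ortho to a large group and meta to the ethylsulfonyl group, gives a number 0.40 log units higher from compound 2 to compound 3 (beyond the scatter). For the compounds shown here, the earlier compounds could not show this, since compound 1 and compound 2 differ in more than one place, so this is the only reading so far of a single change, and it holds for this one position and this one pair of compounds. No measurement among those shown speaks to what lies behind this step.

The compounds shown leave open how a methoxy group, a longer alkoxy chain such as propoxy or an amine on this same aromatic carbon would compare with ethoxy, and so whether the size of the step follows the size of the entering group. They also leave open whether ethoxy in place of hydrogen would give a step of similar size on the ring carrying the ethylsulfonyl group in compound 1.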